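The compounds below may be only part of what the source reports. "The series", "measured", "known", "first", "only" and "open" are said of these compounds alone.

Working notes on the series. Compound 1, `COc1cc(-c2nn(-c3cccc(NC(=O)c4ccc(Cl)c(C(F)(F)F)c4)c3)cc2-c2ccncc2)ccc1Cl`, is the starting point: in a functional assay on HOP-92 cells (Homo sapiens) for inhibition, read by sulforhodamine B assay, with a stated time of 48 h (on this read-out higher numbers stand for weaker inhibition and lower numbers for stronger inhibition), compound 1 gives 670 nM, the highest of the two numbers in hand. The nearest is compound 2, `O=C(Nc1cccc(-n2cc(-c3ccncc3)c(-c3ccc(Cl)c(O)c3)n2)c1)Nc1cc(C(F)(F)F)cc(C(F)(F)F)c1`, which in this assay gives 340 nM; the two values lie within the usual scatter of each other, so no order is read from them. Among the measured compounds shown here, no pair of measured compounds differs in one place, so no measured step is available for any single change.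

Compound 3, `COc1cc(-c2nn(-c3cccc(NC(=O)Nc4cccc(C(F)(F)F)c4)c3)cc2-c2ccncc2)ccc1Cl`, has not yet been measured in this assay. It differs from compound 1 in one place: (3-(trifluoromethyl)phenyl)amino in place of 4-chloro-3-(trifluoromethyl)phenyl on a carbonyl carbon. The leaving group carries no hydrogen-bond donor and the entering group carries one.

With no measured step of this kind in the series, the step of a 1.5-fold lower number from compound 1 to compound 3 (0.17 log units; within the scatter) is expected to be small, downward if anything, and not beyond the scatter. Compound 3 is estimated to give 450 nM in this assay, with a range of 150 nM to 1400 nM.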

Compound 3, half-maximal inhibitory concentration: 560 nM
Compound 3: middle estimate off by 1.2-fold (0.09 log units), on the low side; measured number inside the range.
By their numbers in this assay, from the lowest: compounds 2, 3 and 1 (each within the scatter of the next).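

Among the compounds shown here, this is the first measured single change. In this assay, (3-(trifluoromethyl)phenyl)amino in place of 4-chloro-3-(trifluoromethyl)phenyl on a carbonyl carbon gives a 1.2-fold lower number from compound 1 to compound 3 (0.08 log units; within the scatter), so this position accepts a group with a hydrogen-bond donor and without chlorine, with no change beyond the scatter. No measurement of any property of these groups bears on the result, and nothing can be said about what lies behind it.

The step exchanges a chlorine for a nitrogen in one move, so the compounds shown do not separate the two. A (4-chloro-3-(trifluoromethyl)phenyl)amino group on the same carbonyl carbon would show whether either one matters alone, and a methylamino group would show whether the aromatic ring is needed here at all.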